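This account rests on a few compounds, and the source may have more. Where it says the series, first, only, none or still open, it means among the compounds named here.

Measured so far in a functional assay on A-431 cells (Homo sapiens) for cytotoxicity, read by MTT assay, with a stated time of 72 h, tested at 1 uM; a lower number here means less inhibition of growth, a higher number more inhibition of growth at the concentration tested:
Compound 1, `N/C(=N\NC(=S)N1CCOCC1)c1ccccn1`, gives 29.2%.
Compound 2, `Cc1cccc(/C(N)=N/NC(=S)N2CCSCC2)n1`, gives 42.8%.
Compound 3, `Cc1ccnc(/C(N)=N/NC(=S)N2CCSCC2)c1`, gives 34.6%.

Among these three numbers compound 3 sits second highest, yet its gap to compound 1 and its gap to compound 2 both fall within the usual scatter of this kind of measurement, so the three cannot be told apart with confidence. Compound 4, `N/C(=N\NC(=S)N1CCSCC1)c1ccccn1`, is the next to be measured. It differs from compound 3 by hydrogen in place of methyl on an aromatic carbon. Going by the values given here, no pair of measured compounds shows this change on its own, so no measured step can guide the expectation. The change from compound 3 to compound 4 in this assay is expected to stay within the scatter, with no clear direction: an expected step of a number 0.6 percentage points lower from compound 3 to compound 4 (within the scatter). Compound 4 is therefore estimated at 34%, with a range from 22% to 46%.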

Compound 4, percent growth inhibition at one concentration: 31.7%
Estimate against measurement, compound 4: 2.3 percentage points above, within the range that was stated.
By their numbers in this assay, from the lowest: compounds 1, 4, 3 and 2 (each within the scatter of the next, the first and the last beyond it).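

In this assay, hydrogen in place of the methyl opposite the ring nitrogen leaves growth inhibition within the scatter (a number 2.9 percentage points lower from compound 3 to compound 4 (within the scatter)), whereas removing the methyl from its different place on the ring in compound 2 gives a modest drop (a number 11.1 percentage points lower from compound 2 to compound 4 (beyond the scatter)). Thiomorpholin-4-yl in place of morpholin-4-yl also stays within the scatter (a number 2.5 percentage points higher from compound 1 to compound 4 (within the scatter)). Nothing available explains these steps.

The compounds shown leave open what an amine or an ethyl chain on this aromatic carbon would do. They also leave open what piperidin-1-yl in place of thiomorpholin-4-yl would do.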